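Aromatic nitrogen substituent: 3-hydroxypropoxy to benzyloxy

The source may hold more compounds than are shown below. What is called first, only, known or untested is meant among the compounds shown, and "the series" means these compounds.

In a functional assay on a cell-free system (plasma, Oryctolagus cuniculus) for inhibition, with stated times of 5 min, 1 min and 6 min (on this read-out lower numbers stand for stronger inhibition and higher numbers for weaker inhibition), compound 1 `CCOC(=O)c1[nH]c(-c2cccc(C#N)c2)nc1C` gives > 30000 nM, which is a limit of the assay and not a number. Compound 2 `CCOC(=O)c1c(C)nc(-c2cccc(C#N)c2)n1C` gives 22100 nM. Among the compounds with values here, compound 3 `CCOC(=O)c1c(C)nc(-c2cccc(C#N)c2)n1OCCCO` gives 11400 nM, which stands within the scatter of compound 2 as one of only two true numbers in the set.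

Compound 4 `CCOC(=O)c1c(C)nc(-c2cccc(C#N)c2)n1OCc1ccccc1` carries phenyl in place of 2-hydroxyethyl on a saturated chain carbon bound to an oxygen on an aromatic ring. The same difference reads 3-hydroxypropoxy to benzyloxy.

The bearing steps all change the group on the aromatic nitrogen: an at least 1.3-fold lower number from compound 1 to compound 2 (0.13 log units; that floor lies within the scatter), an at least 2.6-fold lower number from compound 1 to compound 3 (0.42 log units; beyond the scatter) and a 1.9-fold lower number from compound 2 to compound 3 (0.29 log units; within the scatter). All are small, and only the second clears the scatter. None tests a phenyl group at this place, so no direction is set and no step beyond the scatter is expected.

The estimated step is a 1.1-fold lower number from compound 3 to compound 4 (0.06 log units; within the scatter). For compound 4 the expected value is 10000 nM, with an estimated range of 3500 nM to 28000 nM.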

Compound 4, half-maximal inhibitory concentration: 5930 nM
Estimate against measurement, compound 4: 1.7-fold (0.23 log units) above; low and high end bracket the measured number.
By their numbers in this assay, from the lowest: compounds 4, 3 and 2 (each within the scatter of the next, the first and the last beyond it). At a limit, above all of these: compound 1.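

In this assay, phenyl in place of 2-hydroxyethyl leaves the number within the scatter, a 1.9-fold lower number from compound 3 to compound 4 (0.28 log units; within the scatter), so the hydrogen-bond donor of compound 3 is not required to keep this level of inhibition. Benzyloxy is the first oxygen-linked group on the aromatic nitrogen to separate from methyl beyond the scatter, a 3.7-fold lower number from compound 2 to compound 4 (0.57 log units; beyond the scatter), which 3-hydroxypropoxy did not do. Against hydrogen the comparison yields only a floor, an at least 5.0-fold lower number from compound 1 to compound 4 (0.70 log units; beyond the scatter), since compound 1 stands at a limit of the assay and not at a number: the limit of > 30000 nM in this assay, at which 1 of the 4 values shown sits.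

On these data alone, whether the step from methyl depends on the phenyl ring itself or on the oxygen-linked chain remains open. Also open, as far as these compounds go, is whether an amine or a carboxylic acid on the benzyl group, or a longer chain ending in phenyl, would move the number beyond the scatter of compound 4.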